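The source may report more compounds than this note shows. Statements on the series, on what has been measured and on what is new or still open speak of the compounds shown alone.

Measured so far in an assay on isolated protein for displacement of a labelled ligand from metabotropic glutamate receptor 5 (Homo sapiens), with a stated time of 60 min, tested at 1 uM; a higher number here means more inhibition at the concentration tested (going by the name of the read-out), a lower number less inhibition:
compound 1 `CC1CCN(c2c(S(=O)(=O)c3cc(Cl)cc(Cl)c3)cnc3c(F)cccc23)CC1`, 82%
compound 2 `Cc1ccc(S(=O)(=O)c2cnc3cc(Cl)ccc3c2N2CCC(C)CC2)cc1Cl`, 89%

Compound 1 holds the lower of the two numbers, but compound 2 sits within the scatter of it, so no order between them is claimed. Compound 3 `CC1CCN(c2c(S(=O)(=O)c3ccccc3)cnc3c(F)cccc23)CC1` has not been tested. It differs from compound 1 by phenyl in place of 3,5-dichlorophenyl on a sulfonyl sulfur. Among the compounds with values here, no measured pair shows this kind of change, so its size is open; loss of both chlorines on the sulfonyl aryl is expected to lower inhibition beyond the scatter, though the weight of that guess is small. For compound 3 the expected read-out in this assay is 55%, with a range from 25% to 80%, a step of a number 27 percentage points lower from compound 1 to compound 3 (beyond the scatter).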

Compound 3, a percentage reported as inhibition, at one concentration (the size of the read-out at that concentration, not a potency): 13%
Beside the measured number, compound 3's estimate is 42 percentage points above it, and the stated range ends above it.
By their numbers in this assay, from the lowest: compound 3; then compounds 1 and 2 (each within the scatter of the next).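

Within the shared core, the sulfonyl aryl group is not a passive position in this assay: the change to phenyl in place of 3,5-dichlorophenyl on the sulfonyl sulfur gives a number 69 percentage points lower from compound 1 to compound 3 (beyond the scatter). Removing both chlorines together therefore accounts for nearly all of the inhibition held by compound 1 at the tested concentration. Nothing at hand gives a reason for this loss.

On these data alone, whether one chlorine alone would retain inhibition remains open, since both leave together in this step. Also open, as far as these compounds go, is whether methyl, methoxy or trifluoromethyl groups on the phenyl could take the place of the chlorines.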